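This account rests on a few compounds, and the source may have more. Where it says the series, first, only, none or still open, it means among the compounds named here.

In a functional assay on HepG2 cells (Homo sapiens) for cytotoxicity, read by MTT assay, with a stated time of 48 h (on this read-out higher numbers stand for weaker inhibition and lower numbers for stronger inhibition), compound 1 `Cc1ncc([N+](=O)[O-])n1CCSc1nnc(-c2ccccc2Cl)o1` gives 15600 nM, compound 2 `Cc1cccc(-c2nnc(SCCn3c([N+](=O)[O-])cnc3C)o2)c1O` gives 8700 nM and compound 3 `Cc1ncc([N+](=O)[O-])n1CCSc1nnc(-c2cnccc2N)o1` gives 8400 nM, which places compound 3 within the scatter of both others. Compound 4 `Cc1ncc([N+](=O)[O-])n1CCSc1nnc(-c2ccc(N)nc2)o1` differs from compound 3 as follows: 6-aminopyridin-3-yl in place of 4-aminopyridin-3-yl on an aromatic carbon. In words, 6-aminopyridin-3-yl stands in place of 4-aminopyridin-3-yl on an aromatic carbon. Exchanges at this same carbon gave a 1.8-fold lower number from compound 1 to compound 2 (0.25 log units; within the scatter), a 1.9-fold lower number from compound 1 to compound 3 (0.27 log units; within the scatter) and a 1.0-fold lower number from compound 2 to compound 3 (0.02 log units; within the scatter), each within the scatter. Among the measured compounds shown here, no measured step makes this exact exchange, so the support is indirect, and no step beyond the scatter is expected in this assay. The expected step is a 1.1-fold higher number from compound 3 to compound 4 (0.03 log units; within the scatter). For compound 4 the estimated value is 9000 nM, with an expected range of 4000 nM to 20000 nM.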

Compound 4, half-maximal inhibitory concentration: 9400 nM
Beside the measured number, compound 4's estimate is 1.0-fold (0.02 log units) below it; the measured number falls inside the stated range.
By their numbers in this assay, from the lowest: compounds 3, 2, 4 and 1 (each within the scatter of the next).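

In this assay, the isomeric exchange at this carbon gives a 1.1-fold higher number from compound 3 to compound 4 (0.05 log units; within the scatter), so the place of the amino group on the pyridine ring does not separate compound 3 and compound 4 in this read-out. The new aminopyridine also stays within the scatter of both aryl groups on the other side, with a 1.1-fold higher number from compound 2 to compound 4 (0.03 log units; within the scatter) and a 1.7-fold lower number from compound 1 to compound 4 (0.22 log units; within the scatter), so all four groups at this position remain unresolved. No measurement offers an explanation for this flat result.

Still open, on these data alone, is whether a carboxylic acid or a saturated piperidine at this carbon would produce a step beyond the scatter.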